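The source may hold more compounds than are shown below. What is called first, only, known or untested is meant among the compounds shown, and "the series" means these compounds.

Measured so far: compound 1 `O=c1[nH]cc(S(=O)(=O)Nc2ccccc2-c2cn(-c3ccccc3)nn2)c(=O)[nH]1` with > 100000 nM; compound 2 `Cc1ccccc1-n1cc(-c2ccccc2NS(=O)(=O)c2c[nH]c(=O)[nH]c2=O)nn1` with 19900 nM; compound 3 `O=c1[nH]cc(S(=O)(=O)Nc2ccc(-c3cn(-c4ccccc4)nn3)cc2)c(=O)[nH]1` with "not toxic" (no number reported).

In an ADME assay on GES1 cells (Homo sapiens) for cytotoxicity, read by MTT assay, with a stated time of 24 h (a lower number here means that less compound is tolerated, a higher number that more compound is tolerated), compound 1 gives only a limit, > 100000 nM, so its value is not a number. Compound 2 gives 19900 nM in this assay. The two differ by methyl in place of hydrogen on an aromatic carbon, and the step is an at least 5.0-fold lower number from compound 1 to compound 2 (0.70 log units; beyond the scatter); it is reported as "at least" since compound 1 sits at the limit of > 100000 nM in this assay, at which 1 of the 3 values shown sits. Compound 3 gives no number in this assay, only "not toxic" (no number reported). How the core of compound 3 differs from the core of compound 1 is not broken down here. Compound 4 `Cc1ccccc1-n1cc(-c2ccc(NS(=O)(=O)c3c[nH]c(=O)[nH]c3=O)cc2)nn1` is not yet measured; it differs from compound 3 by methyl in place of hydrogen on an aromatic carbon, the same change as from compound 1 to compound 2, with the same place in both. Resting on that earlier step, an at least 5.0-fold lower number from compound 1 to compound 2 (0.70 log units; beyond the scatter), a modest fall from compound 3 to compound 4 is expected. Compound 4 is estimated at 30000 nM, within 10000 nM to 150000 nM, though a limit is also possible.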

Compound 4, half-maximal cytotoxic concentration: "not toxic" (no number reported)
Nothing numeric was reported for compound 4; no gap can be computed for the estimate.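

In this assay, for the compounds shown here, compound 3 gives "not toxic" (no number reported) and compound 4 gives "not toxic" (no number reported), so neither carries a number and no step between them can be read. The compounds shown leave open whether methyl in place of hydrogen on the core of compound 3 would repeat an at least 5.0-fold lower number from compound 1 to compound 2 (0.70 log units; beyond the scatter). That earlier step itself rests on a limit for compound 1: the limit of > 100000 nM in this assay, at which 1 of the 4 values shown sits.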